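Saturating the hydantoin linker in an EP3 antagonist series

A few compounds are considered here, and "the series" means these few. Any claim that something is new, unique, unknown or untested is made for them only; others in the source may bear on it.

Compound 1 `CC(C)C(/C=C1\NC(=O)NC1=O)c1ccc(-c2ccc3cccc(F)c3c2)[nH]c1=O` is a small-molecule antagonist tested in a functional assay on CHO cells for antagonist activity at prostaglandin E2 receptor EP3 subtype (Homo sapiens), read by cAMP accumulation, with a stated time of 30 min (on this read-out higher numbers stand for weaker inhibition and lower numbers for stronger inhibition), where compound 1 gives 87 nM. A close relative, compound 2 `Cc1cc(C(/C=C2\OC(=O)NC2=O)C(C)C)c(=O)[nH]c1-c1ccc2cccc(F)c2c1`, gives 92 nM in this assay; the two numbers lie within the usual scatter of each other, so neither compound stands apart from the other on this read-out. The new analogue is compound 3 `CC(C)C(CC1NC(=O)NC1=O)c1ccc(-c2ccc3cccc(F)c3c2)[nH]c1=O`, which differs from compound 1 in one place: a group of 8 heavy atoms (4 carbon, 2 nitrogen, 2 oxygen; one five-membered non-aromatic ring with 2 hetero atoms) in place of a group of 8 heavy atoms (4 carbon, 2 nitrogen, 2 oxygen; one five-membered non-aromatic ring with 2 hetero atoms), on a saturated chain carbon bound to an aromatic carbon and a saturated chain carbon. The entering group keeps the same ring and the same count of donors and acceptors, but one double bond outside the ring is gone. Among the compounds with values here, no measured pair shows what such a change does, so the expected step of a 2.9-fold higher number from compound 1 to compound 3 (0.46 log units; beyond the scatter) rests on judgement alone and is taken as a modest weakening, a little beyond the scatter. Compound 3 is therefore expected to give about 250 nM in this assay, with a likely range from 80 nM to 800 nM.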

Compound 3, half-maximal inhibitory concentration: 31 nM
Beside the measured number, compound 3's estimate is 8.1-fold (0.91 log units) above it; the whole stated range lies above it.
By their numbers in this assay, from the lowest: compound 3; then compounds 1 and 2 (each within the scatter of the next).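

At this position, on a saturated chain carbon bound to an aromatic carbon and a saturated chain carbon, the double bond outside the ring is not needed for activity. Compounds 1 and 2 both carry that double bond, so they could not show this. Replacing it to give the (2,5-dioxoimidazolidin-4-yl)methyl group produces a 2.8-fold lower number from compound 1 to compound 3 (0.45 log units; beyond the scatter) in this assay, which means stronger inhibition, while the ring and the counts of donors and acceptors stay the same. No evidence here explains why this single change strengthens inhibition.

From the compounds shown here alone, whether the same change in compound 2 would bring a similar step remains open. So does the question of whether a carboxylic acid or a longer chain at this position would keep the gain seen in compound 3.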